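Methyl for Chloro on an Aniline Analogue at the Limit

The source may hold more compounds than are shown below. What is called first, only, known or untested is meant among the compounds shown, and "the series" means these compounds.

Compound 3 `Nc1cccc(/C=C2\SC(=O)N(Cc3ccc(Cl)cc3)C2=O)c1` stands at the upper edge of a functional assay on HeLa cells (Homo sapiens) for cytotoxicity, read by cell counting, with a stated time of 4 days; a higher number here means a weaker inhibitor, a lower number a stronger inhibitor: compound 3 gives > 250000 nM, which is a limit of the assay rather than a number. Compound 2 `Nc1cccc(/C=C2\SC(=O)N(Cc3cccc(F)c3)C2=O)c1` also gives > 250000 nM in this assay, again a limit. The step that the two limits leave unreadable from compound 2 to compound 3 is therefore unreadable. Compound 1 `C=C(Br)C(=O)Nc1cccc(/C=C2\SC(=O)N(Cc3ccc(C)cc3)C2=O)c1`, the only compound shown with a number, gives 1200 nM in this assay. Compound 4 `Cc1ccc(CN2C(=O)S/C(=C\c3cccc(N)c3)C2=O)cc1` differs from compound 3 by methyl in place of chloro on an aromatic carbon. Among the compounds with values here, no measured step reads this change directly; the nearest evidence is the limit of > 250000 nM in this assay, at which 2 of the 3 values shown sit. Compound 4 is expected to remain at that limit, so the step of a number no higher from compound 3 to compound 4 (the limit leaves the size open) is estimated as none beyond the scatter. The estimate for compound 4 is 250000 nM, between 100000 nM and 1000000 nM.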

Compound 4, half-maximal inhibitory concentration: 98000 nM
Compound 4: middle estimate off by 2.6-fold (0.41 log units), on the high side; the measured number lies below the stated range.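

In this assay, methyl in place of chloro gives an at least 2.5-fold lower number from compound 3 to compound 4 (0.40 log units; beyond the scatter), and 4-methylphenyl in place of 3-fluorophenyl gives an at least 2.5-fold lower number from compound 2 to compound 4 (0.40 log units; beyond the scatter), so the group on this ring can move the number even with the free amine in place. Restoring the contrast with the acylated analogue, hydrogen in place of (1-bromoethenyl)carbonyl gives an 82-fold higher number from compound 1 to compound 4 (1.91 log units; beyond the scatter), a first readable size for that change. The free anilines no longer all sit at the limit: the limit of > 250000 nM in this assay, at which 2 of the 4 values shown sit.

The full sizes of the steps from limits, and the step between the two limit compounds, cannot be read. Going by these compounds, how a methoxy group on this aromatic carbon, or an acetyl group on the aniline nitrogen, would read remains open.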